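The source may hold more compounds than are shown below. What is called first, only, known or untested is meant among the compounds shown, and "the series" means these compounds.

The measured compounds:
- compound 1, `C[C@H](NC(=O)c1c(C#Cc2ccc(=O)[nH]c2)sc2c1CCOC2)c1ccc(C(=O)O)cc1`, giving 642 nM in a functional assay on CHO/Galpha16 cells for antagonist activity at prostaglandin E2 receptor EP4 subtype (Homo sapiens), read by calcium flux, with a stated time of 15 min; a lower number here means a stronger inhibitor, a higher number a weaker inhibitor
- compound 2, `CC(=O)N1CCc2c(sc(CCc3ccc(F)cc3)c2C(=O)N[C@@H](C)c2ccc(C(=O)O)cc2)C1`, giving > 1000 nM in this assay, which is a limit of the assay rather than a number

Compound 1 therefore holds the only true number shown in this assay; the other result is a limit, as in the limit of > 1000 nM in this assay, at which 1 of the 2 values shown sits, so compound 2 cannot be set against it in either direction. Compound 3, `C[C@H](NC(=O)c1c(C#Cc2ccc(F)cc2)sc2c1CCOC2)c1ccc(C(=O)O)cc1`, is not yet measured. It differs from compound 1 in one place: a group of 7 heavy atoms (6 carbon, 1 fluorine; one six-membered aromatic ring of carbon only) in place of a group of 7 heavy atoms (5 carbon, 1 nitrogen, 1 oxygen; one six-membered aromatic ring with 1 hetero atom), on a triple-bonded carbon. Going by the values given here, no step between two measured compounds has been worked out, so there is no measured precedent for this change; it is nonetheless expected to move this assay toward a weaker inhibitor by a step somewhat beyond the usual scatter, a 2.8-fold higher number from compound 1 to compound 3 (0.45 log units; beyond the scatter). Compound 3 is accordingly estimated at 1800 nM, with a range from 450 nM to 7000 nM, and a real chance that only a limit is reported.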

Compound 3, half-maximal inhibitory concentration: 15.8 nM
Compound 3: the middle estimate sits 110-fold (2.06 log units) above what was measured; measured number outside the range, below it.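

In this assay the group on the triple-bonded carbon has a strong hold on the result: putting 4-fluorophenyl there gives a 41-fold lower number from compound 1 to compound 3 (1.61 log units; beyond the scatter) with the rest of the molecule unchanged. The group that leaves has 1 hydrogen-bond donor and 1 hydrogen-bond acceptor and 4-fluorophenyl has neither, so this pair shows that a strong inhibitor at this place does not need them. No measured result shown here accounts for the size of the step.

On these data alone, it stays open whether the fluorine contributes at all, which a plain phenyl or a 4-chlorophenyl group at the same place would test. Also open, as far as these compounds go, is whether the triple bond itself matters, which a saturated two-carbon chain carrying the 4-fluorophenyl group on the same core would test.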